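Benzylcarbamoyl in place of benzoyl: an expected small step

The compounds below may be only part of what the source reports. "The series", "measured", "known", "first", "only" and "open" are said of these compounds alone.

In an assay on nucleic acid for inhibition of Nucleic Acid, read by fluorescence, tested at 100 uM (on this read-out lower numbers stand for less inhibition and higher numbers for more inhibition at the one concentration tested (going by the name of the read-out)), compound 1 `CCOC(=O)C1CCCN(Cc2cn(CC(O)COC(=O)c3ccccc3)nn2)C1` gives 6%, the lowest of the three numbers in hand. Compound 3 `CCCCCCCC(=O)OCC(O)Cn1cc(CN2CCN(c3ccccc3)CC2)nn1` gives 26%, a number beyond the scatter above compound 1, and compound 2 `CN(CCCc1ccccc1)Cc1cn(C2CCCCC2OC(=O)COc2ccccc2)nn1` gives 42%, further above still. No pair of these three differs in one place only, so the numbers show which compound inhibits more but not which part of the structure accounts for it.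

Compound 4 `CCOC(=O)C1CCCN(Cc2cn(CC(O)COC(=O)NCc3ccccc3)nn2)C1` is compound 1 with a single change: benzylamino in place of phenyl on a carbonyl carbon. The carbonyl and the aromatic ring both remain; what enters brings one hydrogen-bond donor. Among the compounds with values here, no step of this kind has been measured, so the expectation rests on compound 1 alone, whose 6% leaves room for a rise and little for a fall. The step is expected to be small, a number 4 percentage points higher from compound 1 to compound 4 (within the scatter), and not beyond the scatter. Compound 4 is therefore estimated at 10%, in a range from 0% to 25%.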

Compound 4, a percentage reported as inhibition, at one concentration (the size of the read-out at that concentration, not a potency): 47%
Estimate against measurement, compound 4: 37 percentage points below, and the stated range ends below it.
By their numbers in this assay, from the lowest: compound 1; then compound 3; then compounds 2 and 4 (each within the scatter of the next).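

In this assay, benzylamino in place of phenyl on a carbonyl carbon gives a number 41 percentage points higher from compound 1 to compound 4 (beyond the scatter). Within the data shown here, this is the first single change, and it shows that the read-out responds to this position, which the earlier compounds, with no pair differing in one place, could not show. The six-membered aromatic ring is present on both sides of the step, while benzylamino brings the nitrogen and the hydrogen-bond donor that phenyl lacks, and nothing in hand explains the size of the step.

Going by these compounds, whether the step needs the aromatic ring stays open: methylamino on the same carbonyl carbon would address this, and phenethylamino would test a longer chain. On these data alone, whether benzylamino has the same effect on the carbonyl carbon of compound 3 also stays open.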